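Dimethylamino for acetoxy on a sulfonyl-chalcone scaffold

The compounds below may be only part of what the source reports. "The series", "measured", "known", "first", "only" and "open" are said of these compounds alone.

The measured compounds:
compound 1, `CC(=O)Oc1ccc(/C=C(\C(=O)c2ccc(Cl)cc2)S(=O)(=O)c2ccc(C)cc2)cc1`, 25000 nM
compound 2, `O=C(/C(=C\c1c(O)cc(O)cc1O)SCc1ccc(Cl)cc1Cl)c1ccc(Cl)cc1`, 25000 nM
compound 3, `Cc1ccc(CS/C(=C/c2cc(Cl)cc(Cl)c2)C(=O)c2ccc(Cl)cc2)cc1`, 10000 nM

In a functional assay on DU-145 cells (Homo sapiens) for inhibition, read by trypan blue exclusion, with a stated time of 96 h (on this read-out higher numbers stand for weaker inhibition of growth and lower numbers for stronger inhibition of growth), compound 1 gives 25000 nM, level with compound 2 at the digits shown and together with it the highest number of the three. Compound 3 gives 10000 nM, a lower number that lies beyond the scatter, so on this read-out compound 3 is the stronger inhibitor of growth among the three measured compounds.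

Compound 4, `Cc1ccc(S(=O)(=O)/C(=C/c2ccc(N(C)C)cc2)C(=O)c2ccc(Cl)cc2)cc1`, has not yet been measured in this assay. It differs from compound 1 in one place: dimethylamino in place of acetoxy on an aromatic carbon. Among the compounds with values here, no pair of measured compounds separated by a single change is available, so no step size can be read off for this exchange. An estimate must rest on where compound 1 stands, which is at the upper end of the three numbers. Compound 4 is expected to give a number somewhat lower than compound 1, a step of a 1.7-fold lower number from compound 1 to compound 4 (0.22 log units; within the scatter), though a result within the scatter of compound 1 is not ruled out. Compound 4 is therefore estimated at 15000 nM, with a range from 4000 nM to 50000 nM.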

Compound 4, concentration for 50% growth inhibition: > 100000 nM
Compound 4 was reported as a limit; the forecaster's own chance of this, stated with the estimate: 25%; middle value at least 6.6-fold (0.82 log units) from the limit.
By their numbers in this assay, from the lowest: compound 3; then compounds 1 and 2 (each within the scatter of the next). At a limit, above all of these: compound 4.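

Within the data shown here, this position is not indifferent to the group it carries: in this assay, dimethylamino in place of acetoxy on an aromatic carbon, para to a large group, gives an at least 4.0-fold higher number from compound 1 to compound 4 (0.60 log units; beyond the scatter), the only step here between compounds that differ in one place. Compound 4 gives > 100000 nM, which is a limit of the assay and not a number. The step is therefore a bound, and its true size stays unknown: the limit of > 100000 nM in this assay, at which 1 of the 4 values shown sits.

As far as these compounds go, how a methoxy or a primary amine at this place would read in this assay stays open. From the compounds shown here alone, it is also open whether the same exchange would give a step of similar size on the core of compound 2 or the core of compound 3.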